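Bromophenyl sulfonohydrazides: fluoro addition on the second ring

The source may hold more compounds than are shown below. What is called first, only, known or untested is meant among the compounds shown, and "the series" means these compounds.

Compound 1 `CC(=O)Nc1ccc(S(=O)(=O)NNc2ccc(Br)cc2)cc1` carries a 4-bromophenyl group; in an assay for inhibition of Indoleamine 2,3-dioxygenase 1 (Homo sapiens), read by spectrophotometry, with stated times of 1 h and 4 h (on this read-out lower numbers stand for stronger inhibition and higher numbers for weaker inhibition), compound 1 gives 130 nM. Compound 2 `CC(=O)Nc1ccc(S(=O)(=O)NNc2cccc(Br)c2)cc1` differs in the core: 4-bromophenyl in place of 3-bromophenyl on an amine nitrogen. In this assay compound 2 gives 255 nM, and the step is a 2.0-fold higher number from compound 1 to compound 2 (0.29 log units; within the scatter). Compound 3 `CC(=O)Nc1ccc(S(=O)(=O)NNc2ccc(F)c(Br)c2)cc1` adds a fluoro group to the core of compound 2; in this assay compound 3 gives 128 nM, with the step of a 2.0-fold lower number from compound 2 to compound 3 (0.30 log units; within the scatter). That change is fluoro in place of hydrogen on an aromatic carbon.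

Compound 4 `CC(=O)Nc1ccc(S(=O)(=O)NNc2ccc(Br)c(F)c2)cc1` is not yet measured. It is made from compound 1 by the same kind of change, (fluoro in place of hydrogen on an aromatic carbon). The surroundings differ in printed terms: in compound 3 the entering fluoro group sits para to a large group, in compound 4 meta to a large group, and the cores differ as stated above.

For the measured compounds named here, only the one earlier step, a 2.0-fold lower number from compound 2 to compound 3 (0.30 log units; within the scatter), informs the expectation; that step lies within the scatter. From compound 1 to compound 4 the expected step is a 1.4-fold lower number from compound 1 to compound 4 (0.16 log units; within the scatter), because a 2.0-fold lower number from compound 2 to compound 3 (0.30 log units; within the scatter) gives no reason to expect more. For compound 4 the estimated value in this assay is 90 nM, between 40 nM and 220 nM.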

Compound 4, half-maximal inhibitory concentration: 205 nM
Compound 4: the middle estimate sits 2.3-fold (0.36 log units) below what was measured; measured number inside the range.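

In this assay, fluoro in place of hydrogen on an aromatic carbon gives a 1.6-fold higher number from compound 1 to compound 4 (0.20 log units; within the scatter), a step that taken alone lies within the scatter. Set beside the earlier step, the change does not carry over from one core to the other with the same size or direction: the same change on two cores in this assay, a 2.0-fold lower number (0.30 log units; within the scatter) from compound 2 to compound 3 and a 1.6-fold higher number (0.20 log units; within the scatter) from compound 1 to compound 4, 3.1-fold (0.50 log units) apart, beyond the scatter of two such steps. For the compounds shown here, this shows only that one core is a poor guide to the other for this change; it rests on a single pair of steps, neither of which is beyond the scatter alone, and it does not show why they part, or whether the fluoro group's place, ortho to a bromo group in compound 4, or the rest of the core decides the outcome.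

On these data alone, it remains open whether the gap between the two cores also appears with a chloro, methyl or methoxy group entering on the same carbon. Also open, as far as these compounds go, is how either core responds when an amine or a carboxylic acid stands in place of the bromo group.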